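A urea ring swap in a growth-inhibition series

The source may hold more compounds than are shown below. What is called first, only, known or untested is meant among the compounds shown, and "the series" means these compounds.

Of the compounds shown here, two in this set have been measured in a functional assay on BT-549 cells (Homo sapiens) for inhibition, read by sulforhodamine B assay, with a stated time of 48 h; on this read-out lower numbers stand for stronger inhibition of growth and higher numbers for weaker inhibition of growth. Compound 1, with structure `O=C(Nc1cccc(-n2cc(-c3ccncc3)c(-c3ccc(Cl)c(O)c3)n2)c1)Nc1cccc(C(F)(F)F)c1`, gives 21400 nM in this assay, the higher of the two numbers and so the weaker growth inhibitor of the pair. Compound 2, with structure `COc1cc(-c2nn(-c3cccc(NC(=O)Nc4cc(C(F)(F)F)cc(C(F)(F)F)c4)c3)cc2-c2ccncc2)ccc1Cl`, gives 3060 nM in this assay, and the gap between these two values lies beyond the scatter of the method; compound 2 differs from compound 1 in more than one place, so no single change can be read from that gap.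

Compound 3, with structure `O=C(Nc1cccc(-n2cc(-c3ccncc3)c(-c3ccc(Cl)c(O)c3)n2)c1)Nc1ccc(Cl)c(Cl)c1`, has not been measured. It differs from compound 1 in one place: 3,4-dichlorophenyl in place of 3-(trifluoromethyl)phenyl on an amide-type nitrogen. Within the data shown here, nothing among the measured pairs isolates this change, so there is no direct guide to its size. With only the values of compound 1 and compound 2 to lean on, the step from compound 1 to compound 3 is expected to be small, a 1.4-fold lower number from compound 1 to compound 3 (0.15 log units; within the scatter), most likely within the scatter of this assay. Compound 3 is therefore expected to give about 15000 nM, within a range of 5000 nM to 45000 nM.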

Compound 3, concentration for total growth inhibition: 16100 nM
Compound 3: middle estimate off by 1.1-fold (0.03 log units), on the low side; the measured number falls inside the stated range.
By their numbers in this assay, from the lowest: compound 2; then compounds 3 and 1 (each within the scatter of the next).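

In this assay, putting 3,4-dichlorophenyl in place of 3-(trifluoromethyl)phenyl on an amide-type nitrogen gives a 1.3-fold lower number from compound 1 to compound 3 (0.12 log units; within the scatter), so this read-out does not separate the two compounds. Among these compounds, this is the only comparison so far that isolates a single place, and it shows that at this position, one of these two groups can stand in for the other with no difference beyond the usual scatter, even though the leaving group has 10 heavy atoms and the entering group has 8. No data here bear on why the two groups read alike.

As far as these compounds go, it remains open whether a different kind of group on this nitrogen, such as an unsubstituted phenyl, a pyridine ring or a chain carrying an amine, would shift the number beyond the scatter. Also unresolved is which feature accounts for the lower number of compound 2, as it differs from compound 1 in more than one place, and each of those changes would need its own single-place comparison.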